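Benzyl to hydrogen: compound 2 to compound 4

The compounds below may be only part of what the source reports. "The series", "measured", "known", "first", "only" and "open" are said of these compounds alone.

compound 1 `c1ccc(COC[C@H]2OCC[C@@H](OCc3ccccc3)[C@@H]2OCc2ccccc2)cc1` gives 39300 nM 
compound 2 `O[C@@H]1[C@@H](O)[C@H](Cc2ccccc2)O[C@H](COCc2ccccc2)[C@H]1O` gives "not active" (no number reported) 
compound 3 `O[C@@H]1[C@@H](OCc2ccccc2)[C@H](O)[C@@H](COCc2ccccc2)O[C@H]1Cc1ccccc1` gives 35300 nM 

All readings come from a functional assay on HL-60 cells (Homo sapiens) for antiproliferative activity, read by MTT assay (a lower number here means a stronger inhibitor, a higher number a weaker inhibitor), and cover this series. Compound 2 stands without a number, reported as "not active" (no number reported) with no figure, whereas compound 1 and compound 3 lie within the scatter of each other. Compound 4 `OC[C@H]1O[C@@H](Cc2ccccc2)[C@H](O)[C@@H](O)[C@@H]1O` is still unmeasured. The change is hydrogen in place of benzyl on an oxygen on a saturated carbon and amounts to hydrogen in place of benzyl on an oxygen on a saturated carbon, benzyloxy to hydroxy. With no number for compound 2, no step size can be given. The expectation in this assay is no gain in inhibition, and most likely another reading without a number. Only compound 1 at 39300 nM and compound 3 at 35300 nM give numbers, and both carry more benzyl groups than compound 2 does. Should a number appear, the estimated value for compound 4 is 100000 nM with an expected range from 40000 nM to 300000 nM as a weak reading.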

Compound 4, half-maximal inhibitory concentration: "not active" (no number reported)
No number was reported for compound 4; there is nothing to compare the estimate with.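

Going by these compounds alone, compound 2 and compound 4 both stand without a number in this assay and so yield no step. No evidence bears on this result. The compounds shown leave open what hydrogen in place of benzyl does to activity.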